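A few compounds are considered here, and "the series" means these few. Any claim that something is new, unique, unknown or untested is made for them only; others in the source may bear on it.

Three compounds of one shared core have numbers in an assay on CHO cells for displacement of a labelled ligand from adenosine receptor A3 (Homo sapiens), read by scintillation counting, with a stated time of 3 h; on this read-out higher numbers stand for weaker inhibition and lower numbers for stronger inhibition. Compound 1 `Cn1c(-c2ccc(F)cc2)nc2c(NC3CCCC3)ncnc21` gives 1140 nM in this assay. Compound 2 `CCCn1c(-c2ccccc2)nc2c(NC3CCC3)ncnc21` gives 264 nM, and compound 3 `CCn1c(-c2ccccc2)nc2c(N)ncnc21` gives 5780 nM. Among these three, compound 1 holds the second highest number: compound 2 sits lower by a gap beyond the scatter, and compound 3 sits higher by a gap that is also beyond the scatter. For the measured compounds named here, since compound 2 and compound 3 each differ from compound 1 in more than one place, none of these pairs isolates a single change, and no measured step stands behind what follows.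

The next compound, compound 4 `Cc1cccc(-c2nc3c(NC4CCCC4)ncnc3n2C)c1`, differs from compound 1 in one place: 3-methylphenyl in place of 4-fluorophenyl on an aromatic carbon. The two compounds keep the same cyclopentylamino group and the same methyl on the ring nitrogen.

Going by the values given here, with no measured pair to lean on, the expected step from compound 1 to compound 4 in this assay is estimated as a 1.3-fold lower number from compound 1 to compound 4 (0.10 log units; within the scatter), that is, no change beyond the scatter in either direction. Compound 4 is therefore expected to give about 900 nM in this assay, with a range from 300 nM to 2700 nM.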

Compound 4, inhibition constant: 510 nM
Compound 4: the middle estimate sits 1.8-fold (0.25 log units) above what was measured; the range from low to high includes it.
By their numbers in this assay, from the lowest: compounds 2 and 4 (each within the scatter of the next); then compound 1; then compound 3.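

In this assay, for the compounds shown here, putting 3-methylphenyl in place of 4-fluorophenyl gives a 2.2-fold lower number from compound 1 to compound 4 (0.35 log units; beyond the scatter), a modest step but one beyond the scatter, and it is the first single change in this set that can be read on its own. It shows that the number responds to the aryl group on this aromatic carbon of the five-membered ring, even though the group that leaves and the group that enters have the same heavy-atom count and neither has a hydrogen-bond donor or acceptor. Nothing measured here accounts for the step, so its origin remains unexplained.

This one step swaps fluorine for methyl and also changes where the substituent sits on the phenyl ring, so the compounds shown cannot separate those two changes. They also leave open how this carbon would tolerate a different aromatic group, such as a pyridyl or naphthyl ring, or a phenyl ring carrying a methoxy group, with the cyclopentylamino group and the methyl on the ring nitrogen kept in place.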